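A Nitrile on the Benzoyl Arm of Compound 3

The source may hold more compounds than are shown below. What is called first, only, known or untested is meant among the compounds shown, and "the series" means these compounds.

Compound 1, `N#Cc1ccc(NC(=O)NCc2cnc3scc(-c4ccc(Br)cc4)n23)cc1`: in an assay on isolated protein for inhibition of Indoleamine 2,3-dioxygenase 1 (Homo sapiens), with a stated time of 60 min, tested at 1 uM (a lower number here means less inhibition, a higher number more inhibition at the concentration tested (going by the name of the read-out)), compound 1 gives 97%.
Compound 2, `CC(=O)N(C)CC(=O)NCc1cnc2scc(-c3ccc(Br)cc3)n12`: compound 2 gives 21%.
Compound 3, `CN(CC(=O)NCc1cnc2scc(-c3ccc(Br)cc3)n12)C(=O)c1ccccc1`: compound 3 gives 50%.

Compound 3 stands second of the three: it lies a number 29 percentage points higher from compound 2 to compound 3 (beyond the scatter), and it sits well below compound 1, whose number is the highest of the set. The drop a number 76 percentage points lower from compound 1 to compound 2 (beyond the scatter) shows how far this series can fall when the carbonyl substituent is exchanged. Compound 4, `CN(CC(=O)NCc1cnc2scc(-c3ccc(Br)cc3)n12)C(=O)c1ccc(C#N)cc1`, carries cyano in place of hydrogen on an aromatic carbon. Within the data shown here, no measured step isolates this change; compound 1 holds the same group, but differs from compound 3 in more than one place, so its high number can only hint at the direction. This step is therefore expected to be modest and upward: a number 12 percentage points higher from compound 3 to compound 4 (beyond the scatter). Compound 4 is estimated at 62%, within a range from 40% to 82%.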

Compound 4, a percentage reported as inhibition, at one concentration (the size of the read-out at that concentration, not a potency): 47%
Compound 4: middle estimate off by 15 percentage points, on the high side; low and high end bracket the measured number.
By their numbers in this assay, from the lowest: compound 2; then compounds 4 and 3 (each within the scatter of the next); then compound 1.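

In this assay, cyano on an aromatic carbon para to a large group of the benzoyl arm gives a number 3 percentage points lower from compound 3 to compound 4 (within the scatter), so at this position the nitrile produces no change that can be told from scatter. The 4-cyanophenyl group in place of methyl on the carbonyl carbon gives a number 26 percentage points higher from compound 2 to compound 4 (beyond the scatter), so the gain over methyl survives the nitrile. Nothing available explains either result. As far as these compounds go, it remains open whether an amine or a carboxylic acid at this position would shift the read-out, and how cyano would behave elsewhere on the ring.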